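This account rests on a few compounds, and the source may have more. Where it says the series, first, only, none or still open, it means among the compounds named here.

Compound 2 `COc1ccc(S(=O)(=O)N2CCc3cccc(-c4ccc([N+](=O)[O-])cc4)c32)cc1` is the stronger of the two measured compounds in a functional assay on KB cells (Homo sapiens) for inhibition, with a stated time of 72 h; a lower number here means a stronger inhibitor, a higher number a weaker inhibitor: compound 2 gives 52.5 nM, while compound 1 `COc1ccc(S(=O)(=O)N2CCc3cccc(-c4ccc(N)cc4)c32)cc1` gives 249 nM. Among the compounds with values here, the one measured step, a 4.7-fold lower number from compound 1 to compound 2 (0.68 log units; beyond the scatter), is the only guide available.

Compound 3 `COc1ccc(S(=O)(=O)N2CCc3cccc(-c4ccc(F)cc4)c32)cc1` differs from compound 2 at one place: fluoro in place of nitro on an aromatic carbon. Fluoro is a third kind of group at this position, neither amino nor nitro, so no measured step covers this exact exchange. What the measurements do show is that the group at this position matters, since the amino-to-nitro step moved the number beyond the scatter. Removing the nitro that accompanied the lower number of compound 2 is therefore expected to cost some of that gain, but fluoro is not amino, so the number is not expected to climb all the way back to that of compound 1.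

Compound 3 is therefore estimated to land between the two measured compounds, a 2.3-fold higher number from compound 2 to compound 3 (0.36 log units; beyond the scatter), giving an expected 120 nM with a range from 40 nM to 400 nM.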

Compound 3, half-maximal inhibitory concentration: 86 nM
Beside the measured number, compound 3's estimate is 1.4-fold (0.14 log units) above it, within the range that was stated.
By their numbers in this assay, from the lowest: compounds 2 and 3 (each within the scatter of the next); then compound 1.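

Within this assay the exchange of nitro for fluoro gives a 1.6-fold higher number from compound 2 to compound 3 (0.21 log units; within the scatter) and so shows that the low number at this position does not depend on nitro: fluoro, with 1 heavy atom against 3 and 0 hydrogen-bond acceptors against 2, serves as well within the usual variation of the measurement. The other exchange gives a 2.9-fold lower number from compound 1 to compound 3 (0.46 log units; beyond the scatter) and, read with the earlier amino-to-nitro step, sets the amino compound apart, since the two other groups at this position each go with a clearly lower number than amino does, although three compounds are too few to call this a general pattern. No measurement at hand explains why the groups at this position rank as they do.

Still open, from the compounds shown here alone, is whether other groups on this carbon, such as chloro, methoxy, a carboxylic acid or a bare hydrogen, would fall with compound 2 and compound 3 or with compound 1. The compounds shown also leave open whether fluoro would give a similar number at another place on the same ring.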